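The compounds below may be only part of what the source reports. "The series", "measured", "known", "first", "only" and "open" are said of these compounds alone.

Measured so far:
- compound 1 `O=C(CSc1ncc[nH]1)Nc1ccc2nc(NC(=O)c3ccc(C(F)(F)F)cc3)sc2c1`: 2690 nM
- compound 2 `O=C(CSc1cccc(O)c1)Nc1ccc2nc(NC(=O)c3cccs3)sc2c1`: 7020 nM
- compound 3 `Cn1c(CNC(=O)c2cccs2)nnc1SCC(=O)Nc1cccc(Cl)c1`: > 100000 nM

In a functional assay on HCT-116 cells (Homo sapiens) for antiproliferative activity, read by MTT assay, with a stated time of 72 h (a lower number here means a stronger inhibitor, a higher number a weaker inhibitor), compound 1 gives 2690 nM, the lowest of the two numbers in hand. Compound 2 gives 7020 nM in this assay, a higher number that lies beyond the scatter of the method. Compound 3 returns only a limit of the assay in this assay, namely > 100000 nM; this is the limit of > 100000 nM in this assay, at which 1 of the 3 values shown sits, and not a number, so it is left out of the ranking.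

Among the measured compounds shown here, no pair of measured compounds differs in a single place, so no measured step is available to calibrate the change that leads to the next compound. Compound 4 `O=C(CSc1ccc(Cl)cc1)Nc1ccc2nc(NC(=O)c3ccc(C(F)(F)F)cc3)sc2c1` is compound 1 with 4-chlorophenyl in place of 1H-imidazol-2-yl on a sulfur. The shared core and the amide on the other side of it are unchanged.

For the measured compounds named here, with no comparable step among the measured compounds, the expectation for this assay is a step from compound 1 to compound 4 of no more than the usual scatter, in either direction, with the wider uncertainty reflected in the range. Compound 4 is accordingly estimated at 3000 nM in this assay, between 800 nM and 12000 nM, which corresponds to an expected 1.1-fold higher number from compound 1 to compound 4 (0.05 log units; within the scatter).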

Compound 4, half-maximal inhibitory concentration: 930 nM
Estimate against measurement, compound 4: 3.2-fold (0.51 log units) above; low and high end bracket the measured number.
By their numbers in this assay, from the lowest: compound 4; then compound 1; then compound 2. At a limit, above all of these: compound 3.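

In this assay, among the compounds shown here, the first measured step at this position is 4-chlorophenyl in place of 1H-imidazol-2-yl on a sulfur (a 2.9-fold lower number from compound 1 to compound 4 (0.46 log units; beyond the scatter)), with the shared core and the other amide held constant. The sulfur therefore accepts a six-membered aromatic ring of carbon only, and for this pair activity does not depend on the hydrogen-bond donor and acceptor counted on the 1H-imidazol-2-yl group. No measured property at hand bears on why the number falls.

This single pair does not show whether the step comes from the chlorine or from the ring that carries it, which a plain phenyl on the same sulfur would separate. It also leaves open how a basic amine or a carboxylic acid on that ring would read in this assay.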